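A few compounds are considered here, and "the series" means these few. Any claim that something is new, unique, unknown or untested is made for them only; others in the source may bear on it.

Measured in an ADME assay on cells (Astrocyte, Homo sapiens) for cytotoxicity, read by WST assay, with a stated time of 72 h; a lower number here means a stronger inhibitor, a higher number a weaker inhibitor: compound 1 `O=C(Nc1cccc(Cl)c1)Nc1cc2ncncc2cc1OCc1ccccc1` gives 7400 nM; compound 2 `O=C(Nc1ccccc1F)Nc1cc2ncncc2cc1OCc1cccc(Cl)c1` gives 8700 nM; compound 3 `O=C(Nc1ccc(C(F)(F)F)cc1)Nc1cc2ncncc2cc1OCc1cccc(Cl)c1` gives 8800 nM.

Compound 1 holds the lowest of the three numbers, yet compound 2 and compound 3 both lie within the scatter of it, so the three cannot be told apart. Compound 4 `O=C(Nc1cccc(Cl)c1)Nc1cc2ncncc2cc1OCc1ccccc1Cl` differs from compound 1 by chloro in place of hydrogen on an aromatic carbon. Going by the values given here, no measured step touches this part of the molecule. Among the compounds with values here, the only measured step, a 1.0-fold higher number from compound 2 to compound 3 (0.00 log units; within the scatter), alters the other urea substituent and stays within the scatter, and compound 2 and compound 3 sit close to compound 1 despite their own differences from it. Compound 4 is therefore expected to show a 1.1-fold higher number from compound 1 to compound 4 (0.03 log units; within the scatter), nothing beyond the scatter. The estimate for compound 4 is 8000 nM, within 4000 nM to 16000 nM.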

Compound 4, half-maximal inhibitory concentration: > 10000 nM
Compound 4 gave a limit, no number; the forecaster's own chance of this, stated with the estimate: 5%; middle value at least 1.2-fold (0.09 log units) from the limit.
By their numbers in this assay, from the lowest: compounds 1, 2 and 3 (each within the scatter of the next). At a limit, above all of these: compound 4.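

Compound 4 gave a limit and not a number in this assay: the limit of > 10000 nM in this assay, at which 1 of the 4 values shown sits. The change from benzyl to 2-chlorobenzyl is the only single change shown on this group, and it gives an at least 1.3-fold higher number from compound 1 to compound 4 (0.13 log units; that floor lies within the scatter). That floor does not separate compound 4 from compound 1, so this position may tolerate chloro without any real change, or the true step may be larger. The compounds shown leave open how large the step is. They also leave open what a methoxy group or an amine would do at this same place.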